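The source may report more compounds than this note shows. Statements on the series, on what has been measured and on what is new or still open speak of the compounds shown alone.

In a toxicity assay on THP-1 cells (Homo sapiens) for inhibition (on this read-out lower numbers stand for higher toxicity in this test and higher numbers for lower toxicity in this test), compound 1 `COc1ccc(-c2cnc(NC(=O)C3CCNCC3)n2C)cc1` gives > 100000 nM, which is a limit of the assay and not a number. Compound 2 `Cn1c(-c2ccccc2F)cnc1NC(=O)c1ccc(F)cc1` gives > 100000 nM, and this too is a limit. Among the measured compounds shown here, compound 2 therefore stands with the only other measured compound, at the limit of > 100000 nM in this assay, at which 2 of the 2 values shown sit.

Compound 3 `Cn1c(-c2ccccc2Cl)cnc1NC(=O)c1ccc(F)cc1` differs from compound 2 in one place: chloro in place of fluoro on an aromatic carbon. Put another way, the 2-fluorophenyl of compound 2 becomes the 2-chlorophenyl of compound 3.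

For the measured compounds named here, no measured pair of compounds shows what a single change does in this assay, so there is no direct precedent for this swap. The expectation is for no change beyond the scatter, and it rests on compound 2, whose limit is > 100000 nM. The step expected here is a number no higher from compound 2 to compound 3 (the limit leaves the size open). For compound 3 the estimated value is 100000 nM, with an expected range from 50000 nM to 200000 nM, and the assay may well report only a limit again.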

Compound 3, half-maximal cytotoxic concentration: > 50000 nM
Compound 3 ended at the assay's limit; the forecaster's own chance of this, stated with the estimate: 85%; the middle value lies beyond the limit too.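

In this assay compound 2 and compound 3 both end at limits of the assay rather than at numbers, so the step between them cannot be read. The compounds shown leave open whether chloro in place of fluoro on this aromatic carbon changes toxicity in this test at all, and how any of these compounds would compare on readable values.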